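This account rests on a few compounds, and the source may have more. Where it says the series, first, only, none or still open, it means among the compounds named here.

Three measured compounds share one core and differ only in the group attached on an aromatic carbon of the five-membered ring. Compound 1 `CNc1nc(NCCCN(C)C)c2sc(-c3ccc(-n4cccn4)cc3)cc2n1` carries 1H-pyrazol-1-yl, and in a physicochemical assay for solubility, at pH 2 (on this read-out lower numbers stand for lower solubility and higher numbers for higher solubility), compound 1 gives 217 ug/mL. Compound 2 `CNc1nc(NCCCN(C)C)c2sc(-c3ccc(C(C)=O)cc3)cc2n1` carries acetyl instead. In this assay compound 2 gives only a limit, > 100 ug/mL, so its solubility is not pinned to a number. Compound 3 `CNc1nc(NCCCN(C)C)c2sc(-c3ccc(N4CCNCC4)cc3)cc2n1` carries piperazin-1-yl. For compound 3 this assay likewise returns only a limit, > 100 ug/mL. With two of the three values at a limit, the step that the limit leaves unreadable from compound 1 to compound 2, the step that the limit leaves unreadable from compound 1 to compound 3 and the step that the two limits leave unreadable from compound 2 to compound 3 have no readable size; what is known is the limit of > 100 ug/mL in this assay, at which 2 of the 3 values shown sit.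

Compound 4 `CNc1nc(NCCCN(C)C)c2sc(-c3cncnc3)cc2n1` is not yet measured. Against compound 2 it changes as follows: pyrimidin-5-yl in place of 4-acetylphenyl on an aromatic carbon. Going by the values given here, none of the measured steps offers a readable size, so the effect of this change cannot be taken from them; the only guide is that compound 1 gives a plain number while the other two sit at the limit. The step is therefore expected to be a step that the limit leaves unreadable from compound 2 to compound 4, with no direction secure. For compound 4 the estimate is 200 ug/mL, expected to lie between 80 ug/mL and 500 ug/mL.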

Compound 4, solubility: 214 ug/mL
Compound 4: the middle estimate sits 1.1-fold (0.03 log units) below what was measured, within the range that was stated.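

No size can be read for the change from compound 2 to compound 4, because the value of compound 2 is only a limit and not a number: the limit of > 100 ug/mL in this assay, at which 2 of the 4 values shown sit.

The compounds shown leave open whether, in this assay, putting pyrimidin-5-yl in place of 4-acetylphenyl raises the read-out, lowers it or leaves it within the usual scatter.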